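Pyrimidinyl piperazine analogue of a succinimide series

The compounds below may be only part of what the source reports. "The series", "measured", "known", "first", "only" and "open" are said of these compounds alone.

Measured so far:
compound 1 `CC1(c2ccccc2)CC(=O)N(CC(=O)N2CCN(c3ccc(Cl)cc3)CC2)C1=O`: 300 mg/kg
compound 2 `COc1ccccc1N1CCN(C(=O)CN2C(=O)CC(C)(c3ccccc3)C2=O)CC1`: "not active" (no number reported)
compound 3 `CC1(c2ccccc2)CC(=O)N(CC(=O)N2CCN(c3ccc(Cl)c(Cl)c3)CC2)C1=O`: "not active" (no number reported)

In a functional assay on the whole organism (strain CD-1) with Mus musculus as the target, with a stated time of 2 h (on this read-out lower numbers stand for an effect already at smaller amounts and higher numbers for an effect only at larger amounts of compound), compound 1 gives 300 mg/kg. Compound 2 is reported as "not active" (no number reported), and compound 3 as "not active" (no number reported), so compound 3 has no single number and shares that outcome with one further compound. Compound 4 `CC1(c2ccccc2)CC(=O)N(CC(=O)N2CCN(c3ncccn3)CC2)C1=O` has not been tested. The change from compound 3 is pyrimidin-2-yl in place of 3,4-dichlorophenyl on an amine nitrogen in a ring. Within the data shown here, no measured pair shows what such a change does here, so the expected step is uncertain in size; with only one numbered compound in the set, a value near that of compound 1 is a reasonable guess. Compound 4 is expected to give about 300 mg/kg, within 100 mg/kg to 600 mg/kg.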

Compound 4, minimum effective dose: 100 mg/kg
For compound 4 the middle estimate is 3.0-fold (0.48 log units) above the measured one, within the range that was stated.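

Replacing 4-chlorophenyl with pyrimidin-2-yl on the amine nitrogen in a ring gives a 3.0-fold lower number from compound 1 to compound 4 (0.48 log units; beyond the scatter) in this assay, so this position accepts an aromatic ring with 2 hetero atoms. Compound 3, carrying 3,4-dichlorophenyl, is reported as not active, whereas compound 4 gives 100 mg/kg, so the choice of ring at this position clearly matters. Nothing shown here explains the step. Going by these compounds, it remains open whether a pyridin-2-yl group, with a single ring nitrogen, would match compound 4. The same applies to a plain methyl group in this place.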